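This account rests on a few compounds, and the source may have more. Where it says the series, first, only, none or still open, it means among the compounds named here.

Measured in an ADME assay on microsomes from liver (Homo sapiens) for metabolic stability, read by LC-MS, using NADPH, with a stated time of 10 min, tested at 10 uM; a higher number here means that the compound lasts longer, a lower number that the compound disappears faster:
Compound 1 `Nc1ncnc2c1c(Oc1cc(C(F)(F)F)ccn1)nn2C1CC1`: > 2.41 h, a limit of the assay
Compound 2 `Nc1ncnc2c1c(Oc1cc(C(F)(F)F)ccn1)nn2CC1CC1`: 1.87 h
Compound 3 `CO[C@H]1CC[C@@H](n2nc(Oc3cc(C(F)(F)F)ccn3)c3c(N)ncnc32)CC1`: 0.317 h

The three compounds share one core and differ only in the group on an aromatic nitrogen. In this assay compound 3 has the lowest number of the set, at 0.317 h. The gap to its nearest neighbour is a 5.9-fold lower number from compound 2 to compound 3 (0.77 log units; beyond the scatter).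

Compound 4 `Nc1ncnc2c1c(Oc1cc(C(F)(F)F)ccn1)nn2[C@@H]1CC[C@H](N)C1` carries 3-aminocyclopentyl in place of 4-methoxycyclohexyl on an aromatic nitrogen. Its ring is five-membered, where the ring it replaces is six-membered.

Among the measured compounds shown here, two measured steps bear on this change, since both bring in the group that compound 4 gives up. One is a 5.9-fold lower number from compound 2 to compound 3 (0.77 log units; beyond the scatter), and the other is an at least 7.6-fold lower number from compound 1 to compound 3 (0.88 log units; beyond the scatter). For compound 1 the size of that second step is a floor only because of the limit of > 2.41 h in this assay, at which 1 of the 3 values shown sits. Neither step involves an amino group, so they guide the direction more firmly than the size. A rise in this assay is therefore expected, but one smaller than those two steps. The estimated change is a 3.2-fold higher number from compound 3 to compound 4 (0.50 log units; beyond the scatter). For compound 4 the expected half-life is 1 h, with an estimated range from 0.35 h to 2.4 h.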

Compound 4, half-life: > 2.41 h
Compound 4 was reported as a limit; the forecaster's own chance of this, stated with the estimate: 12%; middle value at least 2.4-fold (0.38 log units) from the limit.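

In this assay, the result shows that this place on the aromatic nitrogen can carry 3-aminocyclopentyl without the loss seen with 4-methoxycyclohexyl, with an at least 7.6-fold higher number from compound 3 to compound 4 (0.88 log units; beyond the scatter). Among these compounds, then, only compound 3 stands apart from the rest, and a non-aromatic ring of carbon at this place does not by itself bring a low number. Against cyclopropylmethyl the change gives an at least 1.2-fold higher number from compound 2 to compound 4 (0.11 log units; that floor lies within the scatter), so no order can be claimed for that pair, and the step between compound 1 and compound 4 cannot be read. Compound 4 gives > 2.41 h, which is a limit, so the top of this set stays unresolved: the limit of > 2.41 h in this assay, at which 2 of the 4 values shown sit.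

Between compound 3 and compound 4, the ring size changes together with the swap of methoxy for an amino group, and the compounds shown do not separate the two. Going by these compounds, it remains open whether a 4-aminocyclohexyl group would behave like 3-aminocyclopentyl or like 4-methoxycyclohexyl, and whether a plain cyclopentyl group would stay at the same limit.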